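This account rests on a few compounds, and the source may have more. Where it says the series, first, only, none or still open, it means among the compounds named here.

Measured compounds:
Compound 1 `CCOc1ccccc1NC1=CC(=O)c2c(nc3n2[C@H]2OC[C@@H](O)[C@H]2OC3)C1=O`: 8300 nM
Compound 2 `O=C1C(Nc2ccc(C(F)(F)F)cc2)=CC(=O)c2c1nc1n2[C@H]2OC[C@@H](O)[C@H]2OC1`: 8920 nM

For the measured compounds named here, in a functional assay on HeLa cells (Homo sapiens) for inhibition, read by sulforhodamine B assay (a lower number here means a stronger inhibitor, a higher number a weaker inhibitor), compound 2 and compound 1 lie within the scatter of each other, the only measured step being a 1.1-fold higher number from compound 1 to compound 2 (0.03 log units; within the scatter). Compound 3 `O=C1C(Nc2ccc(Br)cc2)=CC(=O)c2c1nc1n2[C@H]2OC[C@@H](O)[C@H]2OC1` differs from compound 2 by bromo in place of trifluoromethyl on an aromatic carbon. Going by the values given here, no measured step exchanges one group on that aromatic carbon for another; the single step from compound 1 to compound 2 swaps the whole aryl group and stayed within the scatter, so it bears only loosely on this change. Compound 3 is therefore expected to give a number close to compound 2, with a 1.0-fold lower number from compound 2 to compound 3 (0.02 log units; within the scatter), estimated at 8500 nM within 4000 nM to 18000 nM.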

Compound 3, half-maximal inhibitory concentration: 5220 nM
Estimate against measurement, compound 3: 1.6-fold (0.21 log units) above; the measured number falls inside the stated range.
By their numbers in this assay, from the lowest: compounds 3, 1 and 2 (each within the scatter of the next).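

In this assay, exchanging only the group on this aromatic carbon gives a 1.7-fold lower number from compound 2 to compound 3 (0.23 log units; within the scatter), so bromo and trifluoromethyl at this place cannot be told apart. Exchanging the whole aryl group on the amine nitrogen gives a 1.6-fold lower number from compound 1 to compound 3 (0.20 log units; within the scatter), so 4-bromophenyl and 2-ethoxyphenyl cannot be told apart either. No measurement is available that would explain these results.

On these data alone, whether an amine or a carboxylic acid on this aromatic carbon would stay within the same range remains open. So does the outcome of putting a longer alkyl chain in place of the aryl group on the amine nitrogen.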